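Configurational isomers against the cytosolic enzyme

The source may hold more compounds than are shown below. What is called first, only, known or untested is meant among the compounds shown, and "the series" means these compounds.

Measured so far:
Compound 1 `O=C(O)[C@H]1NC[C@@H](O)[C@H](O)[C@H]1O`: in an assay on isolated protein for inhibition of cytosolic endo-beta-N-acetylglucosaminidase (Homo sapiens), tested at 1000 uM (a lower number here means less inhibition, a higher number more inhibition at the concentration tested (going by the name of the read-out)), compound 1 gives 6.3%.
Compound 2 `O=C(O)[C@H]1NC[C@H](O)[C@H](O)[C@@H]1O`: in this assay compound 2 gives 26%.
Compound 3 `O=C(O)[C@@H]1NC[C@@H](O)[C@@H](O)[C@H]1O`: in this assay compound 3 gives 26%.

Compound 3 stands level with compound 2 at the digits reported, and the two together hold the highest of the three numbers; the furthest from compound 3 is compound 1, the step being a number 19.7 percentage points higher from compound 1 to compound 3 (beyond the scatter). All three share the same atoms and bonds and differ only in configuration as drawn the fact that compounds 1 and 2 differ only in the configuration as drawn the fact that compounds 1 and 3 differ only in the configuration as drawn (the fact that compounds 2 and 3 differ only in the configuration as drawn).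

Compound 4 `O=C(O)[C@H]1NC[C@@H](O)[C@@H](O)[C@@H]1O` is the next isomer. Relative to compound 3: the two compounds have the same atoms and bonds and differ only in configuration as drawn: 2 of 4 stereo elements differ; a stereocentre at a saturated ring carbon is drawn R in compound 3 and S in compound 4; a stereocentre at a saturated ring carbon is drawn S in compound 3 and R in compound 4.

Among the measured compounds shown here, three measured steps bear on this kind of change. Two of them, each also a change of two of four stereo elements, were a number 19.7 percentage points higher from compound 1 to compound 2 (beyond the scatter) and a number 19.7 percentage points higher from compound 1 to compound 3 (beyond the scatter). The third, a full mirror image, was no change at the digits printed from compound 2 to compound 3 (within the scatter). Changes of configuration in this set have therefore moved the read-out in this assay by a modest amount or not at all. Compound 3 already sits at the top of the three numbers, so for compound 4 the expected outcome is either no change beyond the scatter or a modest fall.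

Compound 4 is estimated at 15%, with a range from 3% to 32%. The step this estimate means for compound 4 is expected to be a number 11 percentage points lower from compound 3 to compound 4 (beyond the scatter).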

Compound 4, a percentage reported as inhibition, at one concentration (the size of the read-out at that concentration, not a potency): 28%
Estimate against measurement, compound 4: 13 percentage points below; the measured number falls inside the stated range.
By their numbers in this assay, from the lowest: compound 1; then compounds 2, 3 and 4 (each within the scatter of the next).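

In this assay, a change of two of four stereo elements can now leave the number within the scatter, as in a number 2 percentage points higher from compound 3 to compound 4 (within the scatter) and in a number 2 percentage points higher from compound 2 to compound 4 (within the scatter), whereas every such step seen earlier was beyond it. The count of changed stereo elements therefore does not settle the outcome, since a number 21.7 percentage points higher from compound 1 to compound 4 (beyond the scatter) involves the same count and lies beyond the scatter. Compounds 2, 3 and 4 now sit within the scatter of one another, and compound 1 is the only isomer set apart, with a step to each of the others beyond the scatter; the contrast rests on configuration alone: the fact that compounds 1 and 4 differ only in the configuration as drawn

On these data alone, these numbers come from one high concentration and are not potencies, so any difference among compounds 2, 3 and 4 at lower concentrations remains unknown. As far as these compounds go, all four compounds carry the carboxylic acid, so whether an amide or a methyl ester in its place would keep or lose this level of inhibition stays open, as does the effect of a longer chain on the shared core.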